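The source may report more compounds than this note shows. Statements on the series, on what has been measured and on what is new or still open speak of the compounds shown alone.

Measured so far in a functional assay on HT-29 cells (Homo sapiens) for inhibition, read by sulforhodamine B assay, with a stated time of 48 h; on this read-out higher numbers stand for weaker inhibition of growth and lower numbers for stronger inhibition of growth:
compound 1, `COc1cc(-c2nn(-c3cccc(NC(=O)c4cccc(C(F)(F)F)c4)c3)cc2-c2ccncc2)ccc1Cl`, gives 1390 nM;
compound 2, `COc1cc(-c2nn(-c3cccc(NC(=O)Nc4cccc(C(F)(F)F)c4)c3)cc2-c2ccncc2)ccc1Cl`, gives 748 nM;
compound 3, `COc1cc(-c2nn(-c3cccc(NC(=O)c4ccc(Cl)c(C(F)(F)F)c4)c3)cc2-c2ccncc2)ccc1Cl`, gives 3380 nM.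

Compound 3 thus carries the highest number of the three. It stands apart from its nearest measured neighbour by a 2.4-fold higher number from compound 1 to compound 3 (0.39 log units; beyond the scatter) and from the furthest by a 4.5-fold higher number from compound 2 to compound 3 (0.66 log units; beyond the scatter).

Compound 4, `COc1cc(-c2nn(-c3cccc(NC(=O)c4ccccc4)c3)cc2-c2ccncc2)ccc1Cl`, differs from compound 3 in one place: phenyl in place of 4-chloro-3-(trifluoromethyl)phenyl on a carbonyl carbon. For the measured compounds named here, only one measured step bears on this change, a 2.4-fold higher number from compound 1 to compound 3 (0.39 log units; beyond the scatter), which runs in the opposite direction and covers the chloro alone; no measured step covers the loss of the trifluoromethyl. Because of a 2.4-fold higher number from compound 1 to compound 3 (0.39 log units; beyond the scatter), a modest step back downwards is expected, a 2.3-fold lower number from compound 3 to compound 4 (0.35 log units; beyond the scatter), and compound 4 is expected to give 1500 nM, in a range from 600 nM to 4000 nM.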

Compound 4, concentration for 50% growth inhibition: 392 nM
The estimate for compound 4 lay 3.8-fold (0.58 log units) above the measured number; measured number outside the range, below it.
By their numbers in this assay, from the lowest: compounds 4, 2 and 1 (each within the scatter of the next, the first and the last beyond it); then compound 3.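

In this assay, phenyl in place of 4-chloro-3-(trifluoromethyl)phenyl on the carbonyl carbon gives an 8.6-fold lower number from compound 3 to compound 4 (0.94 log units; beyond the scatter), and hydrogen in place of trifluoromethyl alone gives a 3.5-fold lower number from compound 1 to compound 4 (0.55 log units; beyond the scatter), so the trifluoromethyl, not only the chloro, goes with weaker inhibition of growth here. Phenyl in place of (3-(trifluoromethyl)phenyl)amino gives a 1.9-fold lower number from compound 2 to compound 4 (0.28 log units; within the scatter), so these two groups cannot be told apart. Nothing available explains these differences. The compounds shown leave open whether a fluoro, a methyl, an amine or a carboxylic acid on the phenyl would keep this level of inhibition.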